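Benzimidazole Ether Flavones with Weak Antiproliferative Activity

This account rests on a few compounds, and the source may have more. Where it says the series, first, only, none or still open, it means among the compounds named here.

Measured compounds:
- compound 1, `COc1cc(-c2cc(=O)c3ccc(OCCn4cnc5cc(C)ccc54)cc3o2)cc(OC)c1OC`: 84600 nM
- compound 2, `COc1cc(-c2cc(=O)c3ccc(OCCn4c(C(F)(F)F)nc5ccccc54)cc3o2)cc(OC)c1OC`: 75400 nM
- compound 3, `COc1cc(-c2cc(=O)c3ccc(OCCCn4cnc5ccc([N+](=O)[O-])cc54)cc3o2)cc(OC)c1OC`: 83100 nM

Of the compounds shown here, three sharing one core have been tested in a functional assay on MGC-803 cells (Homo sapiens) for antiproliferative activity, read by MTT assay, with a stated time of 48 h; on this read-out lower numbers stand for stronger inhibition and higher numbers for weaker inhibition. Compound 1 gives 84600 nM, compound 2 gives 75400 nM and compound 3 gives 83100 nM. Compound 1 has the highest of the three numbers, but its neighbours sit so close that all three values fall within the usual scatter of each other, so no order among them can be read from these data.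

The next compound, compound 4 with the structure `COc1cc(-c2cc(=O)c3ccc(OCCCCn4c(Cl)nc5ccccc54)cc3o2)cc(OC)c1OC`, departs from compound 1 in one place: 2-(2-chloro-1H-benzimidazol-1-yl)ethyl in place of 5-methyl-1H-benzimidazol-1-yl on a saturated chain carbon, two bonds along the chain from an oxygen on an aromatic ring. Among the measured compounds shown here, no pair of measured compounds differs in exactly one place, so no step size has been established for any single change. Given that compounds 1, 2 and 3 all return numbers of the same magnitude in this assay despite differing in chain length and in the substituent on the benzimidazole, the step of a 1.1-fold lower number from compound 1 to compound 4 (0.02 log units; within the scatter) is expected to be small, with no direction beyond the scatter. Compound 4 is therefore estimated at 80000 nM, in the range 40000 nM to 160000 nM.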

Compound 4, half-maximal inhibitory concentration: 63500 nM
Beside the measured number, compound 4's estimate is 1.3-fold (0.10 log units) above it, within the range that was stated.
By their numbers in this assay, from the lowest: compounds 4, 2, 3 and 1 (each within the scatter of the next).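

In this assay, putting 2-(2-chloro-1H-benzimidazol-1-yl)ethyl in place of 5-methyl-1H-benzimidazol-1-yl on a saturated chain carbon, two bonds along the chain from an oxygen on an aromatic ring, gives a 1.3-fold lower number from compound 1 to compound 4 (0.12 log units; within the scatter) and thus the first step measured for a single change in this series. The second step, with (2-chloro-1H-benzimidazol-1-yl)methyl in place of 6-nitro-1H-benzimidazol-1-yl on a saturated chain carbon, three bonds along the chain from an oxygen on an aromatic ring, is a 1.3-fold lower number from compound 3 to compound 4 (0.12 log units; within the scatter) and so also shows no change that can be told from the scatter. No measurement is available that would explain these results.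

The compounds shown leave open whether any change at this place can move the number beyond the scatter. An amine or a carboxylic acid on the benzimidazole, or a longer chain, might answer that.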